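The source may hold more compounds than are shown below. What is called first, only, known or untested is meant among the compounds shown, and "the series" means these compounds.

Three measured members of the series share one core and differ only in the halogen carried on the group bound to the aromatic nitrogen: compound 1 `O=C(O)CN1C(=O)/C(=C/c2nc3ccccc3n2Cc2ccc(Br)cc2)SC1=S`, compound 2 `O=C(O)CN1C(=O)/C(=C/c2nc3ccccc3n2Cc2ccc(F)cc2)SC1=S` and compound 3 `O=C(O)CN1C(=O)/C(=C/c2nc3ccccc3n2Cc2ccc(Cl)cc2)SC1=S`. In a functional assay on HeLa cells (Homo sapiens) for cytotoxicity, read by MTT assay, with a stated time of 48 h (a higher number here means a weaker inhibitor, a lower number a stronger inhibitor), compound 1 gives 12900 nM, compound 2 gives 13900 nM and compound 3 gives 8720 nM. Compound 2 holds the highest of the three numbers, but both of its steps stay within the scatter: a 1.1-fold higher number from compound 1 to compound 2 (0.03 log units; within the scatter) and a 1.6-fold lower number from compound 2 to compound 3 (0.20 log units; within the scatter). Compound 4 `O=C(O)CN1C(=O)/C(=C/c2nc3ccccc3n2Cc2cccc(F)c2)SC1=S` is not yet measured and differs from compound 2 by 3-fluorophenyl in place of 4-fluorophenyl on a saturated chain carbon bound to an aromatic nitrogen. Every measured step exchanges one halogen for another in the same place and none shifts a halogen within the ring, so no step beyond the scatter is expected in this assay. Compound 4 is therefore estimated at 13000 nM, with a range from 6500 nM to 26000 nM. The expected step is a 1.1-fold lower number from compound 2 to compound 4 (0.03 log units; within the scatter).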

Compound 4, half-maximal inhibitory concentration: > 50000 nM
Compound 4: only a limit was reported; the forecaster's own chance of this, stated with the estimate: 5%; at least 3.8-fold (0.58 log units) between middle value and limit.
By their numbers in this assay, from the lowest: compounds 3, 1 and 2 (each within the scatter of the next). At a limit, above all of these: compound 4.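

Shifting the fluorine within the ring matters where exchanging one halogen for another did not: 3-fluorophenyl in place of 4-fluorophenyl gives an at least 3.5-fold higher number from compound 2 to compound 4 (0.55 log units; beyond the scatter), though the two have the same atoms. Compared with the other two halogens, the outcome is alike, with an at least 5.7-fold higher number from compound 3 to compound 4 (0.75 log units; beyond the scatter) and an at least 3.8-fold higher number from compound 1 to compound 4 (0.58 log units; beyond the scatter), so in this assay the place of the halogen on this ring counts among these four compounds. The value of compound 4 is a limit, so the full size of these steps stays unknown: the limit of > 50000 nM in this assay, at which 1 of the 4 values shown sits.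

Still open, going by these compounds, is whether chloro or bromo, shifted in the same way, follows fluoro. Also open, on these data alone, is whether a methoxy group or an amine in place of the halogen stays near compound 1, compound 2 and compound 3.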